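This account rests on a few compounds, and the source may have more. Where it says the series, first, only, none or still open, it means among the compounds named here.

In a functional assay on RAW264.7 cells (Mus musculus) for inhibition, with stated times of 2 h and 24 h (a higher number here means a weaker inhibitor, a lower number a stronger inhibitor), compound 1 `COc1ccc([C@@H]2c3c(OC)cc(OC)cc3C(O)[C@H]2c2cc(OC)cc(OC)c2)cc1` gives 7870 nM, the higher of the two numbers available, which makes it the weaker inhibitor of the pair with numbers. Compound 2 `COc1cc(OC)cc([C@@H]2C(O)c3cc(OC)cc(OC)c3[C@H]2c2ccccc2)c1` gives 3380 nM. Compound 3 `COc1cc(OC)cc([C@@H]2C(O)c3cc(OC)cc(OC)c3[C@H]2c2ccc(F)cc2)c1` is reported as "not active" (no number reported), with no number at all.

The step followed here leads to compound 4 `COc1ccc(CSC2c3cc(OC)cc(OC)c3[C@@H](c3ccc(OC)cc3)[C@@H]2c2cc(OC)cc(OC)c2)cc1`, where (4-methoxybenzyl)sulfanyl stands in place of hydroxy on a saturated ring carbon: (4-methoxybenzyl)sulfanyl in place of hydroxy on a saturated ring carbon. Among the measured compounds shown here, no measured step touches this carbon. For the measured compounds named here, the only measured step, a 2.3-fold lower number from compound 1 to compound 2 (0.37 log units; beyond the scatter), is a different change, hydrogen in place of methoxy on an aromatic carbon, and it is modest. It therefore gives only a rough sense of scale and no direction for the new change. The result for compound 3, "not active" (no number reported), also shows that a number cannot be taken for granted in this series. With no evidence for a direction, no step beyond the scatter is expected in this assay, although the uncertainty is wide and the assay may report no number. The expected change is a 1.4-fold lower number from compound 1 to compound 4 (0.16 log units; within the scatter). For compound 4 the estimated value is 5500 nM, with an expected range of 1500 nM to 20000 nM.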

Compound 4, half-maximal inhibitory concentration: 12500 nM
Estimate against measurement, compound 4: 2.3-fold (0.36 log units) below; measured number inside the range.
By their numbers in this assay, from the lowest: compound 2; then compounds 1 and 4 (each within the scatter of the next).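

In this assay, putting (4-methoxybenzyl)sulfanyl in place of hydroxy on the saturated ring carbon gives a 1.6-fold higher number from compound 1 to compound 4 (0.20 log units; within the scatter), so compound 1 and compound 4 cannot be told apart in this pair. Among the compounds shown here, this is the first information on this carbon: in this one pair, a hydroxy group with its hydrogen-bond donor gives way to a group of 10 heavy atoms with no hydrogen-bond donor and a six-membered aromatic ring, and the assay still returns a number close to that of compound 1. No measurement shown accounts for this outcome, and the result rests on this single pair.

The compounds leave open whether the sulfur or the 4-methoxybenzyl part decides the outcome, since a smaller methylsulfanyl group or a benzyloxy group at this carbon would separate the two. They also leave open how an amine or a carboxylic acid would behave there, and whether the same exchange would give a similar result on the core of compound 2, which carries an unsubstituted phenyl group instead of the 4-methoxyphenyl group.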